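From piperidin-1-yl to 4-hydroxypiperidin-1-yl

The source may hold more compounds than are shown below. What is called first, only, known or untested is meant among the compounds shown, and "the series" means these compounds.

compound 1 `CCN(CC)CC(=O)N1N=C(C)CC1c1ccccc1OC(C)=O` gives 33200 nM
compound 2 `CC(=O)Oc1ccccc1C1CC(C)=NN1C(=O)CN(C(C)C)C(C)C` gives 34100 nM
compound 3 `CC(=O)Oc1ccccc1C1CC(C)=NN1C(=O)CN1CCCCC1` gives 19000 nM

These values come from a functional assay on HepG2 cells (Homo sapiens) for cytotoxicity, read by MTT assay, with a stated time of 48 h (a lower number here means a stronger inhibitor, a higher number a weaker inhibitor), and lie close together. Compound 3 stands level with the other two, as a 1.7-fold lower number from compound 1 to compound 3 (0.24 log units; within the scatter) and a 1.8-fold lower number from compound 2 to compound 3 (0.25 log units; within the scatter) show, while a 1.0-fold higher number from compound 1 to compound 2 (0.01 log units; within the scatter) separates those two no further.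

Compound 4 `CC(=O)Oc1ccccc1C1CC(C)=NN1C(=O)CN1CCC(O)CC1` departs from compound 3 by a single change, hydroxy in place of hydrogen on a saturated ring carbon in which piperidin-1-yl becomes 4-hydroxypiperidin-1-yl: hydroxy in place of hydrogen on a saturated ring carbon, three ring bonds from the ring nitrogen.

Among the compounds with values here, no measured step tests a hydroxy group directly. The three steps above all exchange the group on the same saturated chain carbon bound to a carbonyl carbon, and that is the group now altered. None of them leaves the scatter in this assay but they cover only groups without hydroxy, so they guide the estimate loosely. No step beyond the scatter is therefore expected, with only a slight lean towards a higher number. The estimate amounts to a 1.3-fold higher number from compound 3 to compound 4 (0.12 log units; within the scatter) as the expected step. Compound 4 is estimated at 25000 nM with 10000 nM to 60000 nM as its expected range.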

Compound 4, half-maximal inhibitory concentration: 12300 nM
For compound 4 the middle estimate is 2.0-fold (0.31 log units) above the measured one; measured number inside the range.
By their numbers in this assay, from the lowest: compounds 4, 3, 1 and 2 (each within the scatter of the next, the first and the last beyond it).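

In this assay, the core tolerates hydroxy on a saturated ring carbon, three ring bonds from the ring nitrogen: the change gives a 1.5-fold lower number from compound 3 to compound 4 (0.19 log units; within the scatter) and so leaves the two piperidine compounds level. The 4-hydroxypiperidin-1-yl group does, however, open the first gaps beyond the scatter in this small set, with a 2.8-fold lower number from compound 2 to compound 4 (0.44 log units; beyond the scatter) against the diisopropylamino group and a 2.7-fold lower number from compound 1 to compound 4 (0.43 log units; beyond the scatter) against the diethylamino group, both modest, whereas piperidin-1-yl stayed within the scatter of those two groups. No measurement shown here offers an explanation for these gaps.

The compounds shown leave open whether a methoxy group, an amino group or a carboxylic acid on that same saturated ring carbon would stay level with hydroxy or move the number beyond the scatter. They also leave open whether a morpholin-4-yl or piperazin-1-yl group in place of the whole piperidine would match the 4-hydroxypiperidin-1-yl group in this assay.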